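A few compounds are considered here, and "the series" means these few. Any claim that something is new, unique, unknown or untested is made for them only; others in the source may bear on it.

Of the compounds shown here, two have been measured in an assay on membranes from striatum for binding affinity to 5-hydroxytryptamine receptor 4 (Rattus norvegicus); a lower number here means a stronger inhibitor, a higher number a weaker inhibitor. Compound 1, `CC(C)CN1CCC(CNC(=O)c2cc(Cl)cc3[nH]cnc23)CC1`, gives 0.29 nM in this assay. Compound 2, `CCCCN1CCC(CNC(=O)c2cc(Br)cc3[nH]cnc23)CC1`, gives 0.64 nM in this assay. Of the two, compound 2 has the higher number, and its gap to compound 1 lies beyond the usual scatter of such measurements, so compound 2 counts as the weaker binder of the pair.

The next compound, compound 3, `CCCCN1CCC(CNC(=O)c2cc(Br)c(N)c3[nH]cnc23)CC1`, differs from compound 2 in one place: amino in place of hydrogen on an aromatic carbon. Going by the values given here, no pair of measured compounds shows this exact change, so there is no measured step to lean on. The expectation is a small downward step, of a size that could still sit within the scatter, since the measured values of compound 1 and compound 2 give no direct guide. For compound 3 the estimate in this assay is 0.4 nM, with a range from 0.1 nM to 1.5 nM, which means an expected step of a 1.6-fold lower number from compound 2 to compound 3 (0.20 log units; within the scatter).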

Compound 3, inhibition constant: 27.8 nM
Compound 3: middle estimate off by 70-fold (1.84 log units), on the low side, outside the stated range (above it).
By their numbers in this assay, from the lowest: compound 1; then compound 2; then compound 3.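

Placing one amino group on this aromatic carbon, ortho to a bromo group and para to a large group, has a large effect in this assay: the step is a 43-fold higher number from compound 2 to compound 3 (1.64 log units; beyond the scatter), well beyond the scatter. Until now, nothing had tested this position, and this pair shows that binding is highly sensitive to a change there, even one that adds a single heavy atom. No measurement available here bears on the reason for this loss.

Going by these compounds, whether the loss is specific to the amino group or would follow any group at this carbon remains open, and a methyl, hydroxyl or fluoro group there would help separate the two. On these data alone, it is also open whether the step would be the same size with chloro in place of bromo.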